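A few compounds are considered here, and "the series" means these few. Any claim that something is new, unique, unknown or untested is made for them only; others in the source may bear on it.

In a functional assay on MCF7 cells (Homo sapiens) for cytotoxicity, read by MTT assay, with a stated time of 48 h (a lower number here means a stronger inhibitor of growth, a higher number a weaker inhibitor of growth), compound 1 (`OC[C@H]1O[C@@H](n2cnc3cc(F)c(F)cc32)[C@H](O)[C@@H]1O`) gives 57900 nM and compound 2 (`Cn1c(C(F)(F)F)nc2cc(Cl)c(Cl)cc21`) gives 39000 nM, so these two stand within the scatter of each other. Compound 3 (`FC(F)(F)c1nc2cc(Cl)c(Cl)cc2n1CC1CC1`) comes from compound 2 by cyclopropyl in place of hydrogen on a saturated chain carbon bound to an aromatic nitrogen, which reads as methyl to cyclopropylmethyl. Among the measured compounds shown here, no measured step shows what this change does, so only a modest move toward a lower number is expected in this assay, and it may stay within the scatter. The expected change is a 2.0-fold lower number from compound 2 to compound 3 (0.29 log units; within the scatter). For compound 3 the estimated value is 20000 nM, with an expected range from 7000 nM to 55000 nM.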

Compound 3, concentration for 50% growth inhibition: 60200 nM
Compound 3: the middle estimate sits 3.0-fold (0.48 log units) below what was measured; measured number above the stated range.
By their numbers in this assay, from the lowest: compounds 2, 1 and 3 (each within the scatter of the next).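

In this assay, among the compounds shown here, methyl to cyclopropylmethyl gives a 1.5-fold higher number from compound 2 to compound 3 (0.19 log units; within the scatter), the only step measured at this saturated chain carbon bound to an aromatic nitrogen. The added cyclopropyl therefore does not carry the number beyond the scatter, so this place tolerates that group without a readable shift in growth inhibition. Nothing measured here bears on why the step is this small. The compounds shown leave open whether a longer chain, an amine or a carboxylic acid at this place would move the number beyond the scatter.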